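Replacing cyclohexylamino with morpholin-4-yl on a shared core

The compounds below may be only part of what the source reports. "The series", "measured", "known", "first", "only" and "open" are said of these compounds alone.

Measured so far in a functional assay on PC-3 cells (Homo sapiens) for inhibition, read by sulforhodamine B assay, with a stated time of 72 h; a higher number here means a weaker inhibitor, a lower number a stronger inhibitor:
Compound 1 `Nc1sc(-c2ccc(Cl)cc2)c(-c2ccc(Cl)cc2)c1C(=O)NC1CCCCC1` gives 7300 nM.
Compound 2 `Nc1sc(-c2ccc(Cl)cc2)c(-c2ccc(Cl)cc2)c1C(=O)Nc1ccccc1` gives > 50000 nM, which is a limit of the assay.
Compound 3 `CCOC(=O)Nc1sc(-c2ccc(Cl)cc2)c(-c2ccc(Cl)cc2)c1C(=O)NC1CC1` gives 27600 nM.

Among these numbers, compound 1 holds the lowest, at 7300 nM, while compound 3 stands higher at 27600 nM. The next compound, compound 4 `Nc1sc(-c2ccc(Cl)cc2)c(-c2ccc(Cl)cc2)c1C(=O)N1CCOCC1`, keeps the core of compound 1 and carries one change: morpholin-4-yl in place of cyclohexylamino on a carbonyl carbon. This places morpholin-4-yl in place of cyclohexylamino on a carbonyl carbon, so the amide hydrogen of compound 1 is gone. Within the data shown here, only one measured step alters the cyclohexyl group of compound 1, with phenyl taking its place on an amide-type nitrogen: an at least 6.8-fold higher number from compound 1 to compound 2 (0.83 log units; beyond the scatter). That single step is thin support, and it involves a different replacement, but it points towards a higher number in this assay rather than a lower one. A smaller move in the same direction is therefore expected here, and the expected step is a 3.4-fold higher number from compound 1 to compound 4 (0.53 log units; beyond the scatter). Compound 4 is estimated at 25000 nM, with an expected range from 9000 nM to 50000 nM.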

Compound 4, half-maximal inhibitory concentration: 11700 nM
For compound 4 the middle estimate is 2.1-fold (0.33 log units) above the measured one; the range from low to high includes it.
By their numbers in this assay, from the lowest: compounds 1 and 4 (each within the scatter of the next); then compound 3. At a limit, above all of these: compound 2.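

In this assay, morpholin-4-yl on the carbonyl carbon gives a 1.6-fold higher number from compound 1 to compound 4 (0.20 log units; within the scatter), so with the amide hydrogen gone, the number stays within the scatter of the cyclohexylamino amide. The earlier compounds shown here showed only one other replacement of the cyclohexyl group, and this result adds a ring at this position that does not carry the penalty seen with anilino, with an at least 4.2-fold lower number from compound 2 to compound 4 (0.63 log units; beyond the scatter). The value of compound 2 is a limit of the assay, so this second step is a bound and not an exact size: the limit of > 50000 nM in this assay, at which 1 of the 4 values shown sits.

The compounds shown do not separate the loss of the amide hydrogen from the arrival of the ring oxygen. On these data alone, a piperidin-1-yl group on the same carbonyl carbon, which has the ring without that oxygen, remains open, as does a 4-methylpiperazin-1-yl group, which holds an amine in its place.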